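Removing the aryl chloro: from compound 3 to compound 4

The source may report more compounds than this note shows. Statements on the series, on what has been measured and on what is new or still open speak of the compounds shown alone.

In a functional assay on a cell-free system (plasma) for inhibition of thromboxane A2 receptor (Homo sapiens), read by turbidimetry (a higher number here means a weaker inhibitor, a lower number a stronger inhibitor), compound 3 `O=C(O)CC/C=C\C[C@H]1[C@H](F)CC[C@@H]1NS(=O)(=O)c1ccc(Cl)cc1` gives 210 nM, the lowest number of the three measured; compound 1 `O=C(O)CC/C=C\C[C@H]1[C@H](F)CC[C@@H]1NS(=O)(=O)c1ccc(F)cc1` gives 750 nM and compound 2 `O=C(O)COCCCC[C@H]1[C@H](F)CC[C@@H]1NS(=O)(=O)c1ccccc1` gives 1700 nM. Compound 4 `O=C(O)CC/C=C\C[C@H]1[C@H](F)CC[C@@H]1NS(=O)(=O)c1ccccc1` differs from compound 3 by hydrogen in place of chloro on an aromatic carbon. Going by the values given here, one measured step bears on this change: a 3.6-fold lower number from compound 1 to compound 3 (0.55 log units; beyond the scatter), chloro giving the lower number than fluoro. Among the compounds with values here, compound 2 carries the unsubstituted ring on a different chain and gives a higher number than compound 3, but no single-point step connects the two. Removing the chloro altogether is therefore expected to raise the number in this assay by a modest step, a 4.8-fold higher number from compound 3 to compound 4 (0.68 log units; beyond the scatter). Compound 4 is estimated at 1000 nM, with a range of 400 nM to 2500 nM.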

Compound 4, half-maximal inhibitory concentration: 2000 nM
Estimate against measurement, compound 4: 2.0-fold (0.30 log units) below; measured number inside the range.
By their numbers in this assay, from the lowest: compound 3; then compound 1; then compounds 2 and 4 (each within the scatter of the next).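

In this assay, going from 4-chlorophenyl to phenyl is a larger step than the halogen swap alone showed (a 9.5-fold higher number from compound 3 to compound 4 (0.98 log units; beyond the scatter)), and fluoro also gives a lower number than hydrogen at this position (a 2.7-fold higher number from compound 1 to compound 4 (0.43 log units; beyond the scatter)). Both halogens therefore give lower numbers than hydrogen here, with chloro giving the lowest. With the phenyl group, the two chains do not separate (a 1.2-fold higher number from compound 2 to compound 4 (0.07 log units; within the scatter)). No measurement here accounts for the size of these steps.

Still open, going by these compounds, is whether bromo, methyl or methoxy in this place would match chloro. Also open, on these data alone, is whether chloro gives a similar step on the 3-(carboxymethoxy)propyl chain of compound 2.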